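The compounds below may be only part of what the source reports. "The series", "measured", "known", "first", "only" and "open" are said of these compounds alone.

In an ADME assay on cells (Hepatocyte, Homo sapiens) for metabolic stability, with a stated time of 30 min (on this read-out lower numbers stand for a less stable compound and higher numbers for a more stable compound), measured so far:
compound 1 `O=C(OC1CCC(CN2CCN(c3cc(=O)c4cc(C(F)(F)F)cc([N+](=O)[O-])c4s3)CC2)CC1)c1ccccc1`: 56.4%
compound 2 `NC1CCC(CN2CCN(c3cc(=O)c4cc(C(F)(F)F)cc([N+](=O)[O-])c4s3)CC2)CC1`: 83.6%

Compound 2 holds the higher of the two numbers. Compound 3 `CS(=O)(=O)NC1CCC(CN2CCN(c3cc(=O)c4cc(C(F)(F)F)cc([N+](=O)[O-])c4s3)CC2)CC1` differs from it by methylsulfonyl in place of hydrogen on an amine nitrogen. Going by the values given here, only one measured step bears on this, a number 27.2 percentage points higher from compound 1 to compound 2 (beyond the scatter), a modest one that brought in the amino group now being capped. It is a different change, so it guides only loosely. A small fall is expected, perhaps none beyond the scatter, with the estimated step being a number 7.6 percentage points lower from compound 2 to compound 3 (within the scatter). For compound 3 the estimate is 76%, within a range of 58% to 90%.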

Compound 3, percent of the compound remaining: 105%
Compound 3: the middle estimate sits 29 percentage points below what was measured; measured number above the stated range.
By their numbers in this assay, from the lowest: compound 1; then compound 2; then compound 3.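

In this assay, methylsulfonyl on the amine nitrogen gives a number 21.4 percentage points higher from compound 2 to compound 3 (beyond the scatter) and so does not lower the percent remaining; it raises it. The hydrogen on that amine is therefore not needed for the high number of compound 2. Set against benzoyloxy on the same saturated ring carbon, methanesulfonamido gives a number 48.6 percentage points higher from compound 1 to compound 3 (beyond the scatter) as a large step. The data offer nothing that explains this rise. As far as these compounds go, whether an acetyl group on that nitrogen, or an ethyl or longer chain in place of the sulfonyl methyl, would hold the number remains open.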